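Removing the benzyl group from an amide nitrogen in a weak series

The source may hold more compounds than are shown below. What is called first, only, known or untested is meant among the compounds shown, and "the series" means these compounds.

Of the compounds shown here, three built on one shared core have been tested in a functional assay on HeLa cells (Homo sapiens) for inhibition, with a stated time of 72 h; a higher number here means a weaker inhibitor, a lower number a stronger inhibitor. Compound 1 `COC(=O)C[C@H](NC(=O)OCc1ccccc1)C(=O)N(Cc1ccccc1)C1(C(=O)NCc2ccccc2)CCN(Cc2ccccc2)CC1` gives 14000 nM in this assay. Compound 2 `CCC(C)N(C(=O)[C@H](CC(=O)OC)NC(=O)OCc1ccccc1)C1(C(=O)NCc2ccccc2)CCN(Cc2ccccc2)CC1` differs from compound 1 in one place, (sec-butyl in place of benzyl on an amide-type nitrogen), and in this assay compound 2 gives 4300 nM, so that a 3.3-fold lower number from compound 1 to compound 2 (0.51 log units; beyond the scatter). Compound 3 `COC(=O)C[C@H](N)C(=O)N(Cc1ccccc1)C1(C(=O)NCc2ccccc2)CCN(Cc2ccccc2)CC1` differs from compound 1 in another place, (hydrogen in place of benzyloxycarbonyl on an amine nitrogen), and in this assay compound 3 gives 100000 nM, the highest number of the three, so that a 7.1-fold higher number from compound 1 to compound 3 (0.85 log units; beyond the scatter). The difference between compound 2 and compound 3 is not broken down here; their values simply stand far apart in this assay.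

Compound 4 `CCC(C)N(C(=O)[C@@H](N)CC(=O)OC)C1(C(=O)NCc2ccccc2)CCN(Cc2ccccc2)CC1` has not yet been measured. It stands to compound 3 as compound 2 stands to compound 1: sec-butyl in place of benzyl on an amide-type nitrogen. The place of the change reads the same in both pairs, so this is the same change, made on a different core; the two cores differ as described by hydrogen in place of benzyloxycarbonyl on an amine nitrogen in reverse, compound 3 and compound 4 carrying the free amine where compound 1 and compound 2 carry the benzyloxycarbonyl group. Going by the values given here, the only guide is the one measured instance of this change, a 3.3-fold lower number from compound 1 to compound 2 (0.51 log units; beyond the scatter), and it is expected to carry over in size, giving an estimated 3.3-fold lower number from compound 3 to compound 4 (0.52 log units; beyond the scatter). Among the compounds with values here, on that basis compound 4 is expected to give about 30000 nM in this assay, within a range from 10000 nM to 100000 nM, with the caveat that only one prior instance of the change supports this expectation.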

Compound 4, half-maximal inhibitory concentration: > 250000 nM
Compound 4: only a limit was reported (the forecaster's own chance of this, stated with the estimate: 25%); at least 8.3-fold (0.92 log units) between middle value and limit.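

Compound 4 gives > 250000 nM in this assay and that value is a limit of the assay, not a number. On the core with the free amine, sec-butyl in place of benzyl on the amide-type nitrogen gives an at least 2.5-fold higher number from compound 3 to compound 4 (0.39 log units; beyond the scatter) and so reverses the direction seen on the core with benzyloxycarbonyl, which means that this change does not carry over from one core to the other: the same change on two cores in this assay, a 3.3-fold lower number (0.51 log units; beyond the scatter) from compound 1 to compound 2 and an at least 2.5-fold higher number (0.39 log units; beyond the scatter) from compound 3 to compound 4, at least 8.1-fold (0.91 log units) apart, beyond the scatter of two such steps

This rests on a single pair on each core and on a limit, so it fixes neither the true size of the reversal nor its cause, and it says nothing about other cores in the series, while the step for hydrogen in place of benzyloxycarbonyl with sec-butyl present, an at least 58-fold higher number from compound 2 to compound 4 (1.76 log units; beyond the scatter) as a lower bound, also differs from its counterpart with benzyl present: the same change on two cores in this assay, a 7.1-fold higher number (0.85 log units; beyond the scatter) from compound 1 to compound 3 and an at least 58-fold higher number (1.76 log units; beyond the scatter) from compound 2 to compound 4, at least 8.1-fold (0.91 log units) apart, beyond the scatter of two such steps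

From the compounds shown here alone, whether the reversal also appears with other groups on the amide-type nitrogen, such as isopropyl or cyclohexyl, remains open. Also open, going by these compounds, is how the change behaves with an acetyl group on the amine nitrogen, or with a carboxylic acid in place of the methyl ester.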